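Para substituent series on the shared core: trifluoromethoxy analogue

A few compounds are considered here, and "the series" means these few. Any claim that something is new, unique, unknown or untested is made for them only; others in the source may bear on it.

Measured so far:
compound 1 `CCC1=C(O)c2c(oc(-c3ccc(C)cc3)cc2=O)C(CC)(CC)C1=O` gives 0.08 uM
compound 2 `CCC1=C(O)c2c(oc(-c3ccc(C(F)(F)F)cc3)cc2=O)C(CC)(CC)C1=O` gives 10.4 uM
compound 3 `CCC1=C(O)c2c(oc(-c3ccc(O)cc3)cc2=O)C(CC)(CC)C1=O` gives 20.6 uM

All three were read in a functional assay on KBVIN cells (Homo sapiens) for antiproliferative activity, read by sulforhodamine B assay, with a stated time of 3 days; on this read-out lower numbers stand for an effect already at smaller amounts and higher numbers for an effect only at larger amounts of compound. Compound 1 gives the lowest number of the three, and both changes to the group on the aromatic ring move the number far upward: a 130-fold higher number from compound 1 to compound 2 (2.11 log units; beyond the scatter) and a 260-fold higher number from compound 1 to compound 3 (2.41 log units; beyond the scatter). Between compound 2 and compound 3 the difference is small: a 2.0-fold higher number from compound 2 to compound 3 (0.30 log units; within the scatter). Compound 2 thus stands second highest of the three numbers, close to compound 3 and far from compound 1.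

The next compound, compound 4 `CCC1=C(O)c2c(oc(-c3ccc(OC(F)(F)F)cc3)cc2=O)C(CC)(CC)C1=O`, has not been measured. It differs from compound 2 in one place: trifluoromethoxy in place of trifluoromethyl on an aromatic carbon. The two steps that bear on this are the ones leaving compound 1, which show that replacing the methyl by either trifluoromethyl or hydroxy costs much; the step between compound 2 and compound 3 shows that the two replacing groups land close to each other. Trifluoromethoxy keeps the three fluorines and adds one acceptor, so the expectation for this assay is a step from compound 2 that stays within the scatter, with no clear direction: a 1.2-fold higher number from compound 2 to compound 4 (0.06 log units; within the scatter) is the expected step. Compound 4 is therefore estimated at 12 uM, with a range from 4 uM to 40 uM.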

Compound 4, concentration for half-maximal effect: 9.95 uM
The estimate for compound 4 lay 1.2-fold (0.08 log units) above the measured number, and the stated range covers the measured number.
By their numbers in this assay, from the lowest: compound 1; then compounds 4, 2 and 3 (each within the scatter of the next, the first and the last beyond it).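

In this assay, trifluoromethoxy and trifluoromethyl on this aromatic carbon, para to a large group, cannot be told apart (a 1.0-fold lower number from compound 2 to compound 4 (0.02 log units; within the scatter)), so the added oxygen, with its one hydrogen-bond acceptor, leaves no readable mark on the number. Methyl in compound 1 now stands apart from three different replacements, not two, and the newest gap is again large (a 120-fold higher number from compound 1 to compound 4 (2.09 log units; beyond the scatter)); compound 1 is the only compound shown with a low number at this place. Trifluoromethyl in place of the hydrogen on the oxygen of compound 3 gives a modest step just past the scatter (a 2.1-fold lower number from compound 3 to compound 4 (0.32 log units; beyond the scatter)), a separation that compound 2 and compound 3 did not show, and no measurement on hand bears on why these numbers fall as they do.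

Still open, as far as these compounds go, is whether the low number belongs to methyl alone or extends to neighbouring groups such as ethyl, methoxy or chlorine at this place. An amine or a carboxylic acid here also remains untested among the compounds shown, so the series gives no reading of how such groups would sit against compound 1 or against the three higher numbers.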